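The source may report more compounds than this note shows. Statements on the series, on what has been measured and on what is new or still open speak of the compounds shown alone.

Compound 1 `CN1CC2C=C(c3cncc(Cl)c3)CC(C2)C1`: 9.6 nM
Compound 2 `COc1ccccc1Oc1cncc(C2=CC3CNCC(C2)C3)c1`: 1 nM

Of the compounds shown here, two have been measured in an in vitro assay on SH-EP1 cells for displacement of a labelled ligand from Neuronal acetylcholine receptor; alpha4/beta2 (Homo sapiens); on this read-out lower numbers stand for stronger inhibition and higher numbers for weaker inhibition. Compound 1 gives 9.6 nM in this assay, and compound 2 gives 1 nM. Compound 2 therefore has the lowest of the two numbers; its gap to compound 1 lies well beyond the scatter, although the two structures differ in several places at once, so no single change can be credited for it.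

The next compound, compound 3 `COc1cncc(C2=CC3CNCC(C2)C3)c1`, has not yet been measured. It follows from compound 2 by one change: methyl in place of 2-methoxyphenyl on an oxygen on an aromatic ring. Everything else in compound 2 is kept. Among the measured compounds shown here, no measured pair shows this change on its own, so its effect is unknown. Because compound 2 gives 1 nM, only a modest move toward a higher number is expected, and the step of a 3.0-fold higher number from compound 2 to compound 3 (0.48 log units; beyond the scatter) is estimated to stay small. Compound 3 is expected to give about 3 nM, within a range of 0.8 nM to 12 nM.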

Compound 3, inhibition constant: 0.3 nM
Estimate against measurement, compound 3: 10-fold (1.00 log units) above; measured number outside the range, below it.
By their numbers in this assay, from the lowest: compound 3; then compound 2; then compound 1.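

In this assay, replacing the 2-methoxyphenyl on an oxygen on an aromatic ring with methyl gives a 3.3-fold lower number from compound 2 to compound 3 (0.52 log units; beyond the scatter). The lower number shows that, in this pair, the six-membered aromatic ring of the 2-methoxyphenyl group is not needed for strong inhibition: a methyl of 1 heavy atom does better here than a group of 8 heavy atoms. No measurement shown explains why the smaller group gives the lower number.

On these data alone, it remains open how groups of intermediate size on this oxygen would behave, such as ethyl or an unsubstituted phenyl, and whether an amine could take the place of the methoxy group. As far as these compounds go, compound 1 differs from compound 2 and compound 3 in more than one place, so the contribution of its own groups also remains unknown.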